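The source may hold more compounds than are shown below. What is called first, only, known or untested is meant among the compounds shown, and "the series" means these compounds.

Working notes on the series. Compound 3 `CC(C)(N)CC(=O)N[C@@H]1CCc2ccccc2N(Cc2ccc(-c3ccccc3C(=O)O)cc2)C1=O` gives 3 uM in a functional assay (Pituitary gland cell) with Rattus norvegicus as the target (a lower number here means that less compound is needed, a higher number that more compound is needed for the effect), the highest number of the three measured. Compound 1 `CC(C)(N)CC(=O)N[C@@H]1CCc2ccccc2N(Cc2ccc(-c3ccccc3-c3nnnn3CC(=O)O)cc2)C1=O` gives 1 uM and compound 2 `Cn1nnc(-c2ccccc2-c2ccc(CN3C(=O)[C@H](NC(=O)CC(C)(C)N)CCc4ccccc43)cc2)n1` gives 0.3 uM, so compound 3 sits furthest from compound 2 (a 10-fold higher number from compound 2 to compound 3 (1.00 log units; beyond the scatter)) and nearer compound 1 (a 3.0-fold higher number from compound 1 to compound 3 (0.48 log units; beyond the scatter)). Compound 4 `Cn1nnnc1-c1ccccc1-c1ccc(CN2C(=O)[C@H](NC(=O)CC(C)(C)N)CCc3ccccc32)cc1` differs from compound 3 by 1-methyl-1H-tetrazol-5-yl in place of carboxy on an aromatic carbon. The two steps that bear on this are both replacements of carboxy by a tetrazolyl ring: a 10-fold higher number from compound 2 to compound 3 (1.00 log units; beyond the scatter) for 2-methyl-2H-tetrazol-5-yl and a 3.0-fold higher number from compound 1 to compound 3 (0.48 log units; beyond the scatter) for 1-(carboxymethyl)-1H-tetrazol-5-yl. Both read in the same direction, so a lower number is expected for compound 4, probably a 6.0-fold lower number from compound 3 to compound 4 (0.78 log units; beyond the scatter), between those two. The estimate for compound 4 is 0.5 uM, with a range from 0.15 uM to 2 uM.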

Compound 4, concentration for half-maximal effect: 0.5 uM
Compound 4: middle estimate and measured number agree at the digits printed; low and high end bracket the measured number.
By their numbers in this assay, from the lowest: compounds 2, 4 and 1 (each within the scatter of the next, the first and the last beyond it); then compound 3.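

The step of a 6.0-fold lower number from compound 3 to compound 4 (0.78 log units; beyond the scatter) in this assay shows that a second methyl-bearing tetrazolyl group, on this aromatic carbon ortho to a large group, also gives a lower number than carboxy. With a 1.7-fold higher number from compound 2 to compound 4 (0.22 log units; within the scatter) the two methyl tetrazolyl isomers cannot be told apart in this assay. With a 2.0-fold lower number from compound 1 to compound 4 (0.30 log units; within the scatter) the same holds for hydrogen in place of carboxy on the chain carbon bound to the aromatic nitrogen. Open, from the compounds shown here alone, is how a primary carboxamide or a nitrile at this place compares with 1-methyl-1H-tetrazol-5-yl. What lies behind these numbers is not addressed by any evidence in hand.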